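From chloro to trifluoromethyl on the shared core

The compounds below may be only part of what the source reports. "The series", "measured", "known", "first", "only" and "open" are said of these compounds alone.

Of the compounds shown here, two sharing one core have been measured so far. In a functional assay on the whole organism with Rattus norvegicus as the target (on this read-out higher numbers stand for an effect only at larger amounts of compound and lower numbers for an effect already at smaller amounts), compound 1 (`O=C(O)c1cc(-c2ccc(F)cc2)ccc1O`) gives 14 mg/kg and compound 2 (`O=C(O)c1cc(-c2ccc(Cl)cc2)ccc1O`) gives 24 mg/kg as its value. Compound 2 therefore stands level with compound 1 on these numbers, since the gap between them does not exceed the scatter.

The next compound to be read is compound 3 (`O=C(O)c1cc(-c2ccc(C(F)(F)F)cc2)ccc1O`). It differs from compound 2 by one exchange: trifluoromethyl in place of chloro on an aromatic carbon with trifluoromethyl in place of chloro on an aromatic carbon.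

Within the data shown here, only one measured step bears on this exchange. It is a 1.7-fold higher number from compound 1 to compound 2 (0.23 log units; within the scatter) for chloro in place of fluoro on an aromatic carbon, a swap at a comparable kind of carbon that stayed within the scatter. Among the measured compounds shown here, no measured compound carries trifluoromethyl, so this single step is weak guidance, and no shift beyond the scatter is expected in either direction. The expected change is a 1.0-fold higher number from compound 2 to compound 3 (0.02 log units; within the scatter) in this assay as a rough estimate. In this assay the estimate for compound 3 is 25 mg/kg with an expected range from 10 mg/kg to 60 mg/kg on this evidence.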

Compound 3, dose for half-maximal effect: 50 mg/kg
Compound 3: middle estimate off by 2.0-fold (0.30 log units), on the low side; the range from low to high includes it.
By their numbers in this assay, from the lowest: compounds 1 and 2 (each within the scatter of the next); then compound 3.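

In this assay, among these compounds, trifluoromethyl in place of chloro, on an aromatic carbon para to a large group, gives the first step at this position that lies beyond the scatter (a 2.1-fold higher number from compound 2 to compound 3 (0.32 log units; beyond the scatter)). The earlier exchange of fluoro for chloro had stayed within it, so only now does the group at this position show a readable effect on the dose needed. Measured against the fluoro compound the step is larger still (a 3.6-fold higher number from compound 1 to compound 3 (0.55 log units; beyond the scatter)), which sets compound 3 apart from compounds 1 and 2, themselves level with each other, as the compound that needs the largest dose of the three. Nothing at hand accounts for this shift.

On these data alone, whether a methyl, a methoxy or an amine at this position would stand with compounds 1 and 2 or with compound 3 remains open. As far as these compounds go, the carboxylic acid and the hydroxyl of the shared core are the same in all three compounds, so what an exchange at either of them would do to the dose is equally open.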